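Extending the urea of compound 1 toward a chlorophenyl urea

This account rests on a few compounds, and the source may have more. Where it says the series, first, only, none or still open, it means among the compounds named here.

Measured so far:
- compound 1, `COc1cc(NC(C)CCCNC(=O)Nc2ccc(F)cc2)c2ncccc2c1`, gives 26000 nM
- compound 2, `COc1cc(NC(C)CCCNC(=O)Nc2ccc(O)cc2)c2ncccc2c1`, gives 34000 nM

In a functional assay on NCI-H460 cells (Homo sapiens) for inhibition, read by MTT assay, with a stated time of 72 h (a lower number here means a stronger inhibitor, a higher number a weaker inhibitor), compound 1 has the lowest of the two numbers, with compound 2 within the scatter of it, so neither can be called the stronger. Among the measured compounds shown here, the only measured step, a 1.3-fold higher number from compound 1 to compound 2 (0.12 log units; within the scatter), changes the group on the outer ring and does not move the number beyond the scatter. Compound 3, `COc1cc(NC(C)CCCNC(=O)NNC(=O)Nc2ccc(Cl)cc2)c2ncccc2c1`, is a different kind of change: ((4-chlorophenyl)carbamoyl)amino in place of 4-fluorophenyl on an amide-type nitrogen. For the measured compounds named here, no measured step alters this part of the molecule, so the expectation can rest only on the weak numbers of compounds 1 and 2 and on the fact that the outer ring itself tolerated a swap without a shift. For compound 3 the number is therefore expected to stay close to that of compound 1, a step of a 1.0-fold lower number from compound 1 to compound 3 (0.02 log units; within the scatter), with wide uncertainty. The estimate for compound 3 is 25000 nM, expected between 7000 nM and 90000 nM.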

Compound 3, half-maximal inhibitory concentration: 63000 nM
Compound 3: the middle estimate sits 2.5-fold (0.40 log units) below what was measured, and the stated range covers the measured number.
By their numbers in this assay, from the lowest: compounds 1, 2 and 3 (each within the scatter of the next, the first and the last beyond it).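

In this assay, among the compounds shown here, the swap at this amide-type nitrogen is the first change to give a step beyond the scatter (a 2.4-fold higher number from compound 1 to compound 3 (0.38 log units; beyond the scatter)). Measured from compound 2, the same replacement stays within the scatter (a 1.9-fold higher number from compound 2 to compound 3 (0.27 log units; within the scatter)), so the shift is modest and appears only with compound 1 as the reference. The position accepts the larger ((4-chlorophenyl)carbamoyl)amino group, yet this group does not bring the number down from that of compound 1.

No measured evidence accounts for the step from compound 1 to compound 3. The compounds shown leave open whether the extended urea or the chloro group on the outer ring matters more, and whether an amine or a carboxylic acid on that ring would lower the number.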